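Changing the Aryl Group Beside the Core: Compound 3 to 4

A few compounds are considered here, and "the series" means these few. Any claim that something is new, unique, unknown or untested is made for them only; others in the source may bear on it.

Compound 1 `COc1cccc(S(=O)(=O)c2cnc3cc(F)ccc3c2-c2cccc(Cl)c2)c1` gives 2.97 mL/min in an ADME assay on microsomes from liver (Homo sapiens) for metabolic stability, tested at 2.5 uM; a higher number here means faster removal of the compound, a lower number slower removal.
Compound 2 `O=S(=O)(c1ccc(F)c(F)c1)c1cnc2cc(F)ccc2c1-c1cccc(Cl)c1` gives 0.38 mL/min in this assay.
Compound 3 `COc1ccc(-c2c(S(=O)(=O)c3ccc(C)c(C)c3)cnc3cc(F)ccc23)cc1` gives 4.13 mL/min in this assay.

Of the three, compound 3 and compound 1 are within the scatter of each other, while compound 2 lies much lower, beyond it. Compound 4 `Cc1ccc(S(=O)(=O)c2cnc3cc(F)ccc3c2-c2cccc(Cl)c2)cc1C` differs from compound 3 by 3-chlorophenyl in place of 4-methoxyphenyl on an aromatic carbon. Among the compounds with values here, the only measured step, a 7.8-fold lower number from compound 1 to compound 2 (0.89 log units; beyond the scatter), changes the group on the sulfonyl sulfur, not the group on the aromatic carbon, so it does not bear on this change. Compound 4 shares the 3-chlorophenyl group with compound 1, whose value is close to that of compound 3. Compound 4 is therefore expected to show a 1.4-fold lower number from compound 3 to compound 4 (0.14 log units; within the scatter), a step within the scatter. The estimate for compound 4 in this assay is 3 mL/min, with a range from 1.5 mL/min to 6 mL/min.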

Compound 4, intrinsic clearance in a liver preparation (reported as CLH), per the amount of preparation that the assay uses: 4.01 mL/min
Estimate against measurement, compound 4: 1.3-fold (0.13 log units) below; the measured number falls inside the stated range.
By their numbers in this assay, from the lowest: compound 2; then compounds 1, 4 and 3 (each within the scatter of the next).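

In this assay, the swap on the aromatic carbon gives a 1.0-fold lower number from compound 3 to compound 4 (0.01 log units; within the scatter) with the 3,4-dimethylphenyl group held on the sulfonyl sulfur, so 4-methoxyphenyl and 3-chlorophenyl cannot be told apart here. With 3-chlorophenyl held on the aromatic carbon, the group on the sulfonyl sulfur does separate compounds, with an 11-fold higher number from compound 2 to compound 4 (1.02 log units; beyond the scatter) set against a 1.4-fold higher number from compound 1 to compound 4 (0.13 log units; within the scatter) in the same series. Nothing available explains either result.

As far as these compounds go, it remains open whether an amine or a carboxylic acid on that aromatic carbon would read the same. From the compounds shown here alone, it also remains open whether 3,4-difluorophenyl on the sulfonyl sulfur would keep its low number with 4-methoxyphenyl on the aromatic carbon.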